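Para-substituent swap on the arylpiperazine dithiocarbamate

The source may hold more compounds than are shown below. What is called first, only, known or untested is meant among the compounds shown, and "the series" means these compounds.

Measured so far:
- compound 1 `COc1ccc(N2CCN(C(=S)SCc3ccc4nc(N)nc(N)c4c3)CC2)cc1`: 1580 nM
- compound 2 `Nc1nc(N)c2cc(CSC(=S)N3CCN(c4ccc([N+](=O)[O-])cc4)CC3)ccc2n1`: 1470 nM

In a functional assay on MCF7 cells (Homo sapiens) for antiproliferative activity, read by MTT assay, with a stated time of 72 h (a higher number here means a weaker inhibitor, a lower number a stronger inhibitor), compound 1 gives 1580 nM and compound 2 gives 1470 nM; the two lie within the scatter of each other, a 1.1-fold lower number from compound 1 to compound 2 (0.03 log units; within the scatter). Compound 3 `Nc1nc(N)c2cc(CSC(=S)N3CCN(c4ccc(C(F)(F)F)cc4)CC3)ccc2n1` differs from compound 1 by trifluoromethyl in place of methoxy on an aromatic carbon. Within the data shown here, the only step that bears on this, the exchange of the group at the same position from compound 1 to compound 2, moved nothing beyond the scatter, so no shift beyond the scatter is expected for compound 3 either, a 1.1-fold lower number from compound 1 to compound 3 (0.02 log units; within the scatter). Compound 3 is therefore estimated at 1500 nM, in the range 700 nM to 3200 nM.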

Compound 3, half-maximal inhibitory concentration: 7400 nM
The estimate for compound 3 lay 4.9-fold (0.69 log units) below the measured number; the measured number lies above the stated range.
By their numbers in this assay, from the lowest: compounds 2 and 1 (each within the scatter of the next); then compound 3.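

Exchange at this position is not neutral: trifluoromethyl gives a 4.7-fold higher number from compound 1 to compound 3 (0.67 log units; beyond the scatter) and a 5.0-fold higher number from compound 2 to compound 3 (0.70 log units; beyond the scatter) in the same direction, while methoxy and nitro remain within the scatter of each other. Compound 3 is therefore the weakest of the three, and the flat result of the first pair does not hold for every group here. Nothing available accounts for this separation. Open, from the compounds shown here alone, is whether an amine, a carboxylic acid or a chlorine atom at this position would fall with compounds 1 and 2 or with compound 3.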